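The source may report more compounds than this note shows. Statements on the series, on what has been measured and on what is new or still open speak of the compounds shown alone.

Compound 1, `Clc1cccc(Cl)c1Cc1nnc(Nc2ccc(COCc3ccncc3)cc2)o1`, and compound 3, `Clc1cccc(Cl)c1Cc1nnc(Nc2ccc(COCc3cccnc3)cc2)o1`, carry the shared core with an ether-linked pyridine and sit at one level in an ADME assay on MT2 cells (Homo sapiens) for cytotoxicity, read by MTT assay; on this read-out lower numbers stand for higher toxicity in this test and higher numbers for lower toxicity in this test: compound 1 gives 81000 nM and compound 3 gives 81000 nM. The step of no change at the digits printed from compound 1 to compound 3 (within the scatter) lies within the scatter. Compound 2, `O=c1ncccn1SCCc1ccc(Nc2ncc(Cc3c(F)cccc3F)o2)cc1`, reaches only a limit in this assay, where compound 2 gives > 100000 nM; this is the limit of > 100000 nM in this assay, at which 1 of the 3 values shown sits. Compound 4, `Fc1cccc(F)c1Cc1cnc(Nc2ccc(Oc3cccnc3)cc2)o1`, differs from compound 2 by a group of 7 heavy atoms (5 carbon, 1 nitrogen, 1 oxygen; one six-membered aromatic ring with 1 hetero atom) in place of a group of 10 heavy atoms (6 carbon, 2 nitrogen, 1 oxygen, 1 sulfur; one six-membered aromatic ring with 2 hetero atoms), on an aromatic carbon. For the measured compounds named here, no measured step covers this change; the single measured step only moved a pyridine attachment point, and compounds 1 and 3 show that ether-linked pyridines on this core sit near the top of the range. Compound 4 is therefore expected near the ceiling of this assay, with a step of a number no higher from compound 2 to compound 4 (the limit leaves the size open) not beyond the scatter, and compound 4 is estimated at 100000 nM within 50000 nM to 200000 nM.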

Compound 4, half-maximal cytotoxic concentration: 22000 nM
Beside the measured number, compound 4's estimate is 4.5-fold (0.66 log units) above it; measured number outside the range, below it.
By their numbers in this assay, from the lowest: compound 4; then compounds 1 and 3 (each within the scatter of the next). At a limit, above all of these: compound 2.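

In this assay, (pyridin-3-yl)oxy on the aromatic carbon para to a large group gives an at least 4.5-fold lower number from compound 2 to compound 4 (0.65 log units; beyond the scatter). This position therefore responds to the group it carries, which the earlier step, confined to the pyridine attachment point, did not show. The size of the step stays open, since compound 2 stands at a limit of the assay: the limit of > 100000 nM in this assay, at which 1 of the 4 values shown sits.

The compounds shown leave open which part of the departing group accounts for the step. They also leave open how an amine or a carboxylic acid on this carbon would read.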